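The compounds below may be only part of what the source reports. "The series", "measured", "known", "first", "only" and "open" are said of these compounds alone.

Measured compounds:
Compound 1, `COc1ccc(C(=O)/C=C/c2nc3ccccc3cc2-c2ccc(OC)cc2)cc1`, in a functional assay on H184B5F5/M10 cells (Homo sapiens) for antiproliferative activity, read by XTT assay, with a stated time of 72 h (on this read-out lower numbers stand for stronger inhibition and higher numbers for weaker inhibition), gives > 10000 nM, which is a limit of the assay and not a number.
Compound 2, `COc1ccc(-c2cc3ccccc3nc2/C=C/C(=O)c2ccc(OC)cc2OC)cc1`, in this assay gives 6110 nM.

Compound 2 therefore holds the only number shown; the other value is a limit. Within the data shown here, the single measured step, an at least 1.6-fold lower number from compound 1 to compound 2 (0.21 log units; that floor lies within the scatter), came with a methoxy in place of hydrogen on an aromatic carbon, and its floor lies within the scatter. Compound 3, `COc1ccc(-c2cc3ccccc3nc2/C=C/C(=O)c2c(OC)cccc2OC)cc1`, has not been measured. It differs from compound 2 by 2,6-dimethoxyphenyl in place of 2,4-dimethoxyphenyl on a carbonyl carbon: the two methoxy groups on the aryl ketone are arranged differently, while the rest of the molecule is unchanged. Among the measured compounds shown here, the step from compound 1 to compound 2 is the only one that touches this ring, and it was small. For the measured compounds named here, no measured step rearranges substituents on that ring, so no direction can be drawn from the data. The estimate for compound 3 is therefore 6500 nM, with a range of 2000 nM to 20000 nM, and the estimated step of a 1.1-fold higher number from compound 2 to compound 3 (0.03 log units; within the scatter) is expected to stay within the scatter. Compound 1 sits at the limit of > 10000 nM in this assay, at which 1 of the 2 values shown sits, and compound 3 could be expected to end there as well.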

Compound 3, half-maximal inhibitory concentration: 4470 nM
For compound 3 the middle estimate is 1.5-fold (0.16 log units) above the measured one, within the range that was stated.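

Swapping 2,4-dimethoxyphenyl for 2,6-dimethoxyphenyl on the carbonyl carbon is the only rearrangement of the two methoxy groups shown, and in this assay it gives a 1.4-fold lower number from compound 2 to compound 3 (0.14 log units; within the scatter), so this change in their arrangement has no readable effect on the number. Compared with 4-methoxyphenyl on the same carbon, 2,6-dimethoxyphenyl gives an at least 2.2-fold lower number from compound 1 to compound 3 (0.34 log units; beyond the scatter), which makes this the one step at this position that clears the scatter, while the floor of the step with 2,4-dimethoxyphenyl stays within it. That step is only a floor, as compound 1 is a limit of the assay and not a number: the limit of > 10000 nM in this assay, at which 1 of the 3 values shown sits.

The compounds shown leave open whether a hydroxy group, a fluorine or an amine in place of a methoxy group on the ring at the carbonyl carbon would move the number further than the methoxy groups do. From the compounds shown here alone, all three compounds share the rest of the molecule, so the effect of a change elsewhere, such as a carboxylic acid in place of the methoxy group on the other phenyl ring, also stays open.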